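Bromo to Chloro Exchange on the Phenyl Ring

The compounds below may be only part of what the source reports. "The series", "measured", "known", "first", "only" and "open" are said of these compounds alone.

Compound 2 `O=C1COc2ccc(-c3nn(-c4ccc(Br)cc4)cc3-c3ccccc3)cc2N1` gives 81.5% in a functional assay on A549 cells (Homo sapiens) for cytotoxicity, read by colorimetric assay and MTT assay, with a stated time of 3 days, tested at 1 uM (on this read-out higher numbers stand for a weaker effect at the one concentration tested and lower numbers for a stronger effect), the lowest of the two numbers in hand. In this assay compound 1 `COc1ccc(-n2cc(-c3ccccc3)c(-c3ccc4c(c3)NC(=O)CO4)n2)cc1` gives 95.6%. Among the measured compounds shown here, the one measured step, a number 14.1 percentage points lower from compound 1 to compound 2 (beyond the scatter), was modest; it put bromo in place of methoxy on an aromatic carbon. Compound 3 `O=C1COc2ccc(-c3nn(-c4ccc(Cl)cc4)cc3-c3ccccc3)cc2N1` differs from compound 2 by chloro in place of bromo on an aromatic carbon. For the measured compounds named here, no measured step exchanges one halogen for another, so the only guide is that single step, which swapped a methoxy for a bromo and moved the read-out modestly. Bromo and chloro are each a single heavy atom at the same place, so a step in this assay no larger than that one is expected, most likely within the scatter, with a lean back toward the number of compound 1. For compound 3 the estimated value is 86%, with a range from 73% to 98%. The expected step is a number 4.5 percentage points higher from compound 2 to compound 3 (within the scatter).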

Compound 3, a percentage reported as activity, at one concentration (the size of the read-out at that concentration, not a potency): 84.4%
Estimate against measurement, compound 3: 1.6 percentage points above, and the stated range covers the measured number.
By their numbers in this assay, from the lowest: compounds 2 and 3 (each within the scatter of the next); then compound 1.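

In this assay the exchange of one halogen for the other on the aromatic carbon para to a large group gave a number 2.9 percentage points higher from compound 2 to compound 3 (within the scatter) and thus does not separate the 4-bromophenyl from the 4-chlorophenyl compound. Replacing methoxy with chloro gave a number 11.2 percentage points lower from compound 1 to compound 3 (beyond the scatter) and replacing it with bromo gave a number 14.1 percentage points lower from compound 1 to compound 2 (beyond the scatter) so both halogens part from the methoxy compound in the same direction on this read-out. Nothing at hand explains why the two halogens stand together or why they differ from methoxy.

Going by these compounds, whether the same holds for a fluoro, an amine or a carboxylic acid at this place stays open. Each number also comes from a single concentration, so it speaks only of a stronger or weaker effect at that concentration.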